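A few compounds are considered here, and "the series" means these few. Any claim that something is new, unique, unknown or untested is made for them only; others in the source may bear on it.

Measured so far:
- compound 1, `c1ccc(OCc2nc3c(OCCCN4CCCCC4)cccc3n2CCCC2CCNCC2)cc1`: 4.5 nM
- compound 2, `CN1CCC(CCCn2c(COc3ccccc3)nc3c(OCCCN4CCCCC4)cccc32)CC1`: 1.62 nM

Both values come from an in vitro assay on AV12 cells for binding affinity to Neuropeptide Y receptor type 1 (Homo sapiens); on this read-out lower numbers stand for stronger inhibition and higher numbers for weaker inhibition. Within these two numbers compound 1 stands highest, and its nearest neighbour is compound 2, reached by the step of a 2.8-fold lower number from compound 1 to compound 2 (0.44 log units; beyond the scatter), which swaps a hydrogen for a methyl on the same ring nitrogen that is altered here.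

The new compound 3, `O=C(CCN1CCC(CCCn2c(COc3ccccc3)nc3c(OCCCN4CCCCC4)cccc32)CC1)c1ccccc1`, arises from compound 1 by the change (2-benzoylethyl in place of hydrogen on an amine nitrogen in a ring). For the measured compounds named here, only one measured step touches that nitrogen, and it shows a modest lowering when a small group replaces the hydrogen. The entering group is far larger than a methyl, so the measured step gives a direction but not a size; a change of similar magnitude, in the same direction, is the expectation, with wide uncertainty.

Compound 3 is therefore expected to give about 2.5 nM in this assay, within a range of 0.6 nM to 10 nM, which corresponds to an expected step of a 1.8-fold lower number from compound 1 to compound 3 (0.26 log units; within the scatter).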

Compound 3, inhibition constant: 0.112 nM
Compound 3: middle estimate off by 22-fold (1.35 log units), on the high side, outside the stated range (below it).
By their numbers in this assay, from the lowest: compound 3; then compound 2; then compound 1.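

On this ring nitrogen, a group much larger than methyl is not only accepted in this assay but also brings far stronger inhibition: the 2-benzoylethyl group gives a 40-fold lower number from compound 1 to compound 3 (1.60 log units; beyond the scatter) as a large step, whereas methyl gave only a modest one. The two groups also differ when set directly against each other, with a 14-fold lower number from compound 2 to compound 3 (1.16 log units; beyond the scatter) showing that what is attached to this nitrogen matters, not merely the loss of its hydrogen. Nothing available here explains why the 2-benzoylethyl group does so much better.

The compounds shown leave open which part of the 2-benzoylethyl group matters most: the carbonyl, the aromatic ring or the length of the chain. A 3-phenylpropyl group, which has an aromatic ring but no carbonyl, or a plain ethyl group would help to separate these parts.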